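The compounds below may be only part of what the source reports. "The series", "measured", "known", "first", "only" and "open" are said of these compounds alone.

The three compounds share one core and differ only in the group carried on a saturated chain carbon bound to an oxygen on an aromatic ring. Compound 1 `COc1cccc(OC)c1OCCNCCOc1ccccc1OCc1ccccc1` gives 0.0676 nM in an assay on CHO cells for displacement of a labelled ligand from Alpha-1D adrenergic receptor (Homo sapiens); a lower number here means a stronger inhibitor, a higher number a weaker inhibitor. Compound 2 `COc1cccc(OC)c1OCCNCCOc1ccccc1OCc1ccc(Cl)cc1` gives 0.0316 nM in this assay, and the step of a 2.1-fold lower number from compound 1 to compound 2 (0.33 log units; beyond the scatter) is modest. Compound 3 `COc1cccc(OC)c1OCCNCCOc1ccccc1OCc1cccc(C)c1` gives 0.2 nM in this assay, the highest of the three numbers; the steps of a 3.0-fold higher number from compound 1 to compound 3 (0.47 log units; beyond the scatter) and a 6.3-fold higher number from compound 2 to compound 3 (0.80 log units; beyond the scatter) both lie beyond the scatter. Compound 4 `COc1cccc(OC)c1OCCNCCOc1ccccc1OCc1ccccc1[N+](=O)[O-]` differs from compound 3 by 2-nitrophenyl in place of 3-methylphenyl on a saturated chain carbon bound to an oxygen on an aromatic ring. Within the data shown here, no measured step introduces a 2-nitrophenyl, so the steps that bear on it are those that changed the group on that chain carbon, a 2.1-fold lower number from compound 1 to compound 2 (0.33 log units; beyond the scatter) and a 3.0-fold higher number from compound 1 to compound 3 (0.47 log units; beyond the scatter), both modest and in opposite directions. Since compound 3 stands at the high end of the range set by compound 1 at 0.0676 nM and compound 2 at 0.0316 nM, a return toward those numbers is expected rather than a further rise. For compound 4 the estimate is 0.1 nM, with a range from 0.025 nM to 0.4 nM. The expected step of a 2.0-fold lower number from compound 3 to compound 4 (0.30 log units; within the scatter) is therefore small, toward a lower number, and may fall within the scatter.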

Compound 4, inhibition constant: 0.912 nM
Beside the measured number, compound 4's estimate is 9.1-fold (0.96 log units) below it; measured number outside the range, above it.
By their numbers in this assay, from the lowest: compound 2; then compound 1; then compound 3; then compound 4.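

In this assay, among these compounds, the group on the saturated chain carbon bound to an oxygen on an aromatic ring proves able to shift the number much further than the earlier compounds showed, with a 29-fold higher number from compound 2 to compound 4 (1.46 log units; beyond the scatter) and a 13-fold higher number from compound 1 to compound 4 (1.13 log units; beyond the scatter) both large, whereas every earlier step was modest. With a 4.6-fold higher number from compound 3 to compound 4 (0.66 log units; beyond the scatter) on top of these, compound 4 has the highest number of the four, beyond the scatter from each of the others, so in compound 3 and compound 4 a group added to the unsubstituted ring of compound 1 raises the number, while compound 2 goes against this pattern. Nothing available explains why the 2-nitrophenyl stands so far above the other groups.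

The compounds shown leave open whether the rise belongs to the nitro group itself or to where it sits on the ring, since compound 4 alone carries one. They also leave open how an amine or a nitrile on this ring would read in this assay and whether either would follow compound 2 or compound 4.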